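The compounds below may be only part of what the source reports. "The series", "measured", "known", "first", "only" and "open" are said of these compounds alone.

Compound 1 `Cc1ccc2[nH]c(=O)c(CN(Cc3ccccc3)Cc3ccc(C(C)(C)C)cc3)cc2c1` — in a toxicity assay on MDCK cells (Canis lupus familiaris) for cytotoxicity, read by crystal violet staining, with a stated time of 48 h (on this read-out lower numbers stand for higher toxicity in this test and higher numbers for lower toxicity in this test), compound 1 gives > 5000 nM, a limit of the assay.
Compound 2 `Cc1ccc2[nH]c(=O)c(CN(CCCO)Cc3ccc(C(C)(C)C)cc3)cc2c1` — compound 2 gives > 10000 nM, again a limit.
Compound 3 `Cc1ccc2[nH]c(=O)c(CN(Cc3ccc(C#N)cc3)Cc3ccc(C(C)(C)C)cc3)cc2c1` — compound 3 gives > 5000 nM, also a limit.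

Compound 3 thus stands at the limit of > 5000 nM in this assay, at which 2 of the 3 values shown sit, together with compound 1, while compound 2 stands at the limit of > 10000 nM in this assay, at which 1 of the 3 values shown sits. None of the steps among the three is readable: a step that the two limits leave unreadable from compound 1 to compound 2, a step that the two limits leave unreadable from compound 1 to compound 3, a step that the two limits leave unreadable from compound 2 to compound 3. The next compound, compound 4 `Cc1ccc2[nH]c(=O)c(CN(Cc3ccc(C(C)(C)C)cc3)C(C)c3ccc(OC(F)F)cc3)cc2c1`, differs from compound 3 by 1-(4-(difluoromethoxy)phenyl)ethyl in place of 4-cyanobenzyl on an amine nitrogen. For the measured compounds named here, no measured step bears on this change; the three readings show only that no member of the series has yet returned a number. Compound 4 is therefore expected to remain near the limits, with an estimated step that the limit leaves unreadable from compound 3 to compound 4 not beyond the scatter. The estimate for compound 4 is 8000 nM, range 2500 nM to 30000 nM.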

Compound 4, half-maximal cytotoxic concentration: > 5000 nM
Compound 4: a limit, no number (the forecaster's own chance of this, stated with the estimate: 60%); the middle value does not contradict the limit.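

Compound 4 gives > 5000 nM, a limit, so its steps from compound 1, compound 2 and compound 3 cannot be read. The compounds shown leave open at what concentration any of them becomes cytotoxic, and whether changes on the amine nitrogen alter it.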